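This account rests on a few compounds, and the source may have more. Where it says the series, first, only, none or still open, it means among the compounds named here.

Measured so far:
Compound 1, `Nc1nc(O)c2c(n1)n(C1OC(CO)[C@@H](O)[C@H]1O)c(=O)n2CC(O)CSc1ccccc1` — 142 uM
Compound 2, `CCOC(=O)Cn1c(=O)n(C2OC(CO)[C@@H](O)[C@H]2O)c2nc(N)nc(O)c21` — 48 uM
Compound 3, `Nc1nc(O)c2c(n1)n(C1OC(CO)[C@@H](O)[C@H]1O)c(=O)n2Cc1ccc(OCc2ccccc2)cc1` — 8 uM

Of the compounds shown here, three sharing one core have been measured in a functional assay (B cells) with Mus musculus as the target; a lower number here means that less compound is needed, a higher number that more compound is needed for the effect. Among the compounds with values here, compound 1 gives 142 uM and compound 2 gives 48 uM; the single step between them, a 3.0-fold lower number from compound 1 to compound 2 (0.47 log units; beyond the scatter), comes from an ethoxycarbonyl in place of 1-hydroxy-2-(phenylsulfanyl)ethyl on a saturated chain carbon bound to an aromatic nitrogen. Compound 3, at 8 uM, stands lowest of the three: its gap to compound 2 and its gap to compound 1 both lie beyond the scatter.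

Compound 4, `N#Cc1ccc(Cn2c(=O)n(C3OC(CO)[C@@H](O)[C@H]3O)c3nc(N)nc(O)c32)cc1`, has not yet been measured. It differs from compound 3 in one place: cyano in place of benzyloxy on an aromatic carbon. Within the data shown here, no measured step touches this aromatic carbon, so the only step available, from compound 1 to compound 2, concerns a different part of the molecule and bears on the change only loosely. What the numbers do show is that the compound carrying the largest group at the aromatic nitrogen, compound 3, also gives the lowest number, while the smaller groups of compounds 1 and 2 give higher ones. On that basis a higher number is expected for compound 4 in this assay, a step of a 3.8-fold higher number from compound 3 to compound 4 (0.57 log units; beyond the scatter), with the estimate for compound 4 being 30 uM and a range from 10 uM to 100 uM.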

Compound 4, concentration for half-maximal effect: 15 uM
Beside the measured number, compound 4's estimate is 2.0-fold (0.30 log units) above it; the range from low to high includes it.
By their numbers in this assay, from the lowest: compounds 3 and 4 (each within the scatter of the next); then compound 2; then compound 1.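

In this assay, replacing benzyloxy, with its six-membered aromatic ring and 8 heavy atoms, with the 2 heavy atoms of cyano on the same aromatic carbon leaves the result within the scatter (a 1.9-fold higher number from compound 3 to compound 4 (0.27 log units; within the scatter)), so in this pair the ring of the benzyloxy group is not required for a number at this level. The other two steps set 4-cyanophenyl on the saturated chain carbon bound to an aromatic nitrogen against the earlier groups there (a 3.2-fold lower number from compound 2 to compound 4 (0.51 log units; beyond the scatter); a 9.5-fold lower number from compound 1 to compound 4 (0.98 log units; beyond the scatter)), which shows that a benzyl-type group with a small cyano substituent already goes with a lower number than ethoxycarbonyl or 1-hydroxy-2-(phenylsulfanyl)ethyl, although the latter also holds an aromatic ring. No measurement shown here explains why the two substituents on the aromatic carbon give results within the scatter.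

These compounds leave open whether this tolerance extends to other groups on that aromatic carbon, such as an amine, a carboxylic acid or a methoxy group. They also do not show what a plain benzyl group, with only hydrogen on that carbon, would give.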